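The source may report more compounds than this note shows. Statements on the series, on what has been measured and on what is new or still open speak of the compounds shown alone.

Measured so far:
compound 1, `NC(=O)c1c(NC(=O)c2ccccc2Cl)sc2c1CCN(C(=O)Nc1c(Cl)cccc1Cl)C2`: 17700 nM in a functional assay on HL-60 cells (Homo sapiens) for antiproliferative activity, with a stated time of 24 h; on this read-out lower numbers stand for stronger inhibition and higher numbers for weaker inhibition
compound 2, `NC(=O)c1c(NC(=O)c2ccccc2Br)sc2c1CCN(C(=S)Nc1ccccc1Cl)C2`: 14600 nM in this assay

In this assay compound 2 sits within the usual scatter of compound 1, so the two numbers show no difference worth reading. Compound 3, `CSc1ccccc1C(=O)Nc1sc2c(c1C(N)=O)CCN(C(=S)Nc1ccccc1Cl)C2`, is not yet measured. It differs from compound 2 by methylsulfanyl in place of bromo on an aromatic carbon. With only two measured points and no shown step between them, the change is expected to give no step beyond the scatter, as a 1.0-fold lower number from compound 2 to compound 3 (0.02 log units; within the scatter). For compound 3 in this assay the estimate is 14000 nM, with a range from 6000 nM to 35000 nM.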

Compound 3, half-maximal inhibitory concentration: 30500 nM
Compound 3: the middle estimate sits 2.2-fold (0.34 log units) below what was measured; the range from low to high includes it.
By their numbers in this assay, from the lowest: compounds 2, 1 and 3 (each within the scatter of the next, the first and the last beyond it).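

In this assay, going by these compounds alone, methylsulfanyl in place of bromo on this aromatic carbon, ortho to a large group, gives a 2.1-fold higher number from compound 2 to compound 3 (0.32 log units; beyond the scatter) as the first step beyond the scatter. This position is therefore not indifferent to the group it carries, although the step is modest and rests on a single pair. No available evidence accounts for the step.

As far as these compounds go, whether methoxy, an amine or a longer chain such as ethylsulfanyl here would read closer to compound 2 or compound 3 stays open. Also open, from the compounds shown here alone, is whether the same change gives a similar step on another compound of the series.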